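Cycloalkyl and benzyl amines on the chlorinated purine core

The source may hold more compounds than are shown below. What is called first, only, known or untested is meant among the compounds shown, and "the series" means these compounds.

Measured so far:
- compound 1 `O[C@@H]1[C@H](O)[C@@H]2C[C@@H]2[C@H]1n1cnc2c(NC3CCC3)nc(Cl)nc21`: 5.9 nM
- compound 2 `O[C@@H]1[C@H](O)[C@@H]2C[C@@H]2[C@H]1n1cnc2c(NC3CCCCCCC3)nc(Cl)nc21`: 1530 nM
- compound 3 `O[C@@H]1[C@H](O)[C@@H]2C[C@@H]2[C@H]1n1cnc2c(NCc3ccccc3F)nc(Cl)nc21`: 41.5 nM

Compound 3 stands second of the three in an assay on CHO cells for displacement of a labelled ligand from adenosine receptor A3 (Homo sapiens), with a stated time of 60 min; a higher number here means a weaker inhibitor, a lower number a stronger inhibitor. It sits nearest to compound 1, with the step of a 7.0-fold higher number from compound 1 to compound 3 (0.85 log units; beyond the scatter), and furthest from compound 2, with the step of a 37-fold lower number from compound 2 to compound 3 (1.57 log units; beyond the scatter). The step of a 260-fold higher number from compound 1 to compound 2 (2.41 log units; beyond the scatter) frames the spread of the series on the nitrogen substituent.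

Compound 4 `COc1ccc(F)c(F)c1CNc1nc(Cl)nc2c1ncn2[C@H]1[C@H](O)[C@H](O)[C@@H]2C[C@@H]21` differs from compound 3 in one place: 2,3-difluoro-6-methoxyphenyl in place of 2-fluorophenyl on a saturated chain carbon bound to a nitrogen on an aromatic ring. Within the data shown here, none of the measured steps alters the substituents on the phenyl ring; the steps from compound 1 to compound 3 and from compound 2 to compound 3 concern only the exchange of the whole nitrogen substituent, one modest and one large. The benzyl arrangement is kept in compound 4, so the measured steps give no direct guide and the step is expected to be small, within or just beyond the scatter, in either direction. In this assay compound 4 is expected to give 60 nM, in the range 15 nM to 250 nM, which means an expected step of a 1.4-fold higher number from compound 3 to compound 4 (0.16 log units; within the scatter).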

Compound 4, inhibition constant: 83.2 nM
For compound 4 the middle estimate is 1.4-fold (0.14 log units) below the measured one; the measured number falls inside the stated range.
By their numbers in this assay, from the lowest: compound 1; then compounds 3 and 4 (each within the scatter of the next); then compound 2.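

In this assay the first change made to the phenyl ring itself gives a 2.0-fold higher number from compound 3 to compound 4 (0.30 log units; within the scatter) and so stays within the scatter. The larger 2,3-difluoro-6-methoxyphenyl, which carries a hydrogen-bond acceptor that 2-fluorophenyl lacks, therefore gives a result that cannot be told apart from that of 2-fluorophenyl, whereas each exchange of the whole nitrogen substituent lies beyond the scatter. Nothing measured here explains this result.

The compounds shown leave open how the added fluorine and the methoxy group would each read alone on the phenyl ring, as they enter together in compound 4. Also open, as far as these compounds go, is how an amine or a carboxylic acid on that ring would read, and how a cyclohexyl group on the nitrogen would compare with compound 1 and compound 2.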